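From Chlorophenyl to Dimethoxyphenyl on the Shared Core

The compounds below may be only part of what the source reports. "The series", "measured", "known", "first", "only" and "open" are said of these compounds alone.

Three compounds share one core, and a fourth is to be tested. Compound 1 `CCCCCCCCCCCCNc1nc(SCc2ccc(C(F)(F)F)cc2)nc2ccccc12` and compound 2 `CCCCCCCCCCCCCCNc1nc(SCc2ccc(C(F)(F)F)cc2)nc2ccccc12` carry chains on the ring nitrogen of the core, while compound 3 `FC(F)(F)c1ccc(CSc2nc(Nc3cccc(Cl)c3)c3ccccc3n2)cc1` carries a 3-chlorophenyl there. Going by the values given here, in a functional assay on MDA-MB-231 cells (Homo sapiens) for cytotoxicity, read by MTT assay, with a stated time of 72 h (on this read-out lower numbers stand for stronger inhibition and higher numbers for weaker inhibition), compound 3 gives 18000 nM, the only number among the three. Compound 1 gives > 50000 nM, which is a limit of the assay rather than a number. Compound 2 likewise gives > 50000 nM, again a limit. Because of the limit of > 50000 nM in this assay, at which 2 of the 3 values shown sit, the step that the two limits leave unreadable from compound 1 to compound 2 cannot be read, and its size stays hidden.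

Compound 4 `COc1ccc(Nc2nc(SCc3ccc(C(F)(F)F)cc3)nc3ccccc23)c(OC)c1` differs from compound 3 in one place: 2,4-dimethoxyphenyl in place of 3-chlorophenyl on a nitrogen on an aromatic ring. Among the compounds with values here, no measured step in this set exchanges one aromatic ring for another on that nitrogen, so none of the measured steps bears on this change. Within the data shown here, the single number of compound 3 set against two limits says nothing about such a swap. The expectation is therefore a step no larger than the usual scatter, with a wide spread to either side. Compound 4 is expected to give 18000 nM, within 6000 nM to 50000 nM. The step expected is no change at the digits printed from compound 3 to compound 4 (within the scatter).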

Compound 4, half-maximal inhibitory concentration: > 50000 nM
Compound 4: only a limit was reported (the forecaster's own chance of this, stated with the estimate: 30%); at least 2.7-fold (0.44 log units) between middle value and limit.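

Going by these compounds alone, until now, the only number on this nitrogen on an aromatic ring belonged to compound 3, so nothing showed how the assay would respond to a different aromatic group there. Putting 2,4-dimethoxyphenyl in place of 3-chlorophenyl gives an at least 2.7-fold higher number from compound 3 to compound 4 (0.44 log units; beyond the scatter) in this assay, which shows that a swap between these two groups can move the read-out beyond the usual scatter, even though each brings one six-membered aromatic ring of carbon only. The real size of this step stays unknown because compound 4 reached a limit, so the figure gives only a minimum: the limit of > 50000 nM in this assay, at which 3 of the 4 values shown sit.

The compounds shown leave open whether the step comes from losing the chlorine or from gaining the two methoxy groups, and a plain phenyl on the same nitrogen would help to separate those two parts of the change. They also leave open what a phenyl ring carrying a carboxylic acid or an amine would do at this position, and whether any aromatic group there can give a lower number than compound 3 does.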